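Swapping 3-nitrophenyl for 4-chlorophenyl

A few compounds are considered here, and "the series" means these few. Any claim that something is new, unique, unknown or untested is made for them only; others in the source may bear on it.

In a functional assay on HepG2 cells (Homo sapiens) for antiproliferative activity, read by MTT assay, with a stated time of 24 h (on this read-out lower numbers stand for stronger inhibition and higher numbers for weaker inhibition), compound 1 `COc1ccc(C(=O)/C=C/c2ccc(-n3ccnc3)cc2)c2c1C=CC(C)(C)O2` records > 10000 nM as a limit, not a number. Within the data shown here, compound 2 `COc1ccc(C(=O)/C=C/c2cccc([N+](=O)[O-])c2)c2c1C=CC(C)(C)O2` gives 2830 nM as the only true number so far. Compound 3 `COc1ccc(C(=O)/C=C/c2ccc(Cl)cc2)c2c1C=CC(C)(C)O2` keeps the shared core. The change 4-chlorophenyl in place of 3-nitrophenyl on a double-bonded chain carbon bound to a double-bonded chain carbon puts 4-chlorophenyl in place of 3-nitrophenyl on a double-bonded chain carbon bound to a double-bonded chain carbon. Among the measured compounds shown here, no measured pair shows this swap alone, so a modest weakening of a 1.6-fold higher number from compound 2 to compound 3 (0.20 log units; within the scatter) is only expected, not known. Compound 3 is estimated at 4500 nM with a range from 1500 nM to 10000 nM as the expected bounds.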

Compound 3, half-maximal inhibitory concentration: > 10000 nM
Compound 3: no number, only a limit; the forecaster's own chance of this, stated with the estimate: 25%; middle value at least 2.2-fold (0.34 log units) from the limit.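

In this assay, putting 4-chlorophenyl in place of 3-nitrophenyl on a double-bonded chain carbon bound to a double-bonded chain carbon gives an at least 3.5-fold higher number from compound 2 to compound 3 (0.54 log units; beyond the scatter). Among these compounds, this is the first readable step at this position, and it shows that the read-out responds to the group placed here. Compound 3 records only a limit, so the full size of that step is unknown, and the step between the two limits cannot be read: the limit of > 10000 nM in this assay, at which 2 of the 3 values shown sit.

The swap changes both the substituent and its place on the ring, so the data cannot separate these two changes. On these data alone, whether an amine or a carboxylic acid on this phenyl ring would give a lower number also stays open.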